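The source may report more compounds than this note shows. Statements on the series, on what has been measured and on what is new or still open speak of the compounds shown alone.

Measured so far:
compound 1 `Cc1ccc(N2C(=O)COc3ccc(-c4cnc5ccccc5c4)cc32)cc1` — > 40000 nM
compound 2 `O=C1COc2ccc(-c3cnc(Cl)c(NS(=O)(=O)c4ccc(F)cc4)c3)cc2N1c1ccccc1` — 35700 nM
compound 3 `O=C1COc2ccc(-c3cnc4ccccc4c3)cc2N1c1ccccc1` — > 40000 nM

In a functional assay on HepG2 cells (Homo sapiens) for antiproliferative activity, read by MTT assay, with a stated time of 72 h (on this read-out lower numbers stand for stronger inhibition and higher numbers for weaker inhibition), compound 1 gives > 40000 nM, which is a limit of the assay and not a number. Compound 3 likewise gives > 40000 nM, again a limit. Going by the values given here, compound 2 gives 35700 nM, the only number in the set. The change from compound 1 to compound 3, hydrogen in place of methyl on an aromatic carbon, yields a step that the two limits leave unreadable from compound 1 to compound 3, since both ends sit at the limit of > 40000 nM in this assay, at which 2 of the 3 values shown sit. Compound 4 `O=C1COc2ccc(-c3cnc(Cl)c(NS(=O)(=O)c4ccc(F)cc4)c3)cc2N1C1CCCCC1` differs from compound 2 by cyclohexyl in place of phenyl on an amide-type nitrogen in a ring. Among the compounds with values here, no measured step touches the amide-type nitrogen in a ring, so no direction is supported. Compound 4 is expected at about 35000 nM, within 12000 nM to 100000 nM. The expected step is a 1.0-fold lower number from compound 2 to compound 4 (0.01 log units; within the scatter), within the scatter, with a real chance that only a limit is reported.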

Compound 4, half-maximal inhibitory concentration: > 40000 nM
Compound 4 was reported as a limit; the forecaster's own chance of this, stated with the estimate: 50%; at least 1.1-fold (0.05 log units) between middle value and limit.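

Cyclohexyl in place of phenyl gives the first step at the amide-type nitrogen in a ring: an at least 1.1-fold higher number from compound 2 to compound 4 (0.04 log units; that floor lies within the scatter). In this assay, as far as these compounds go, compound 4 gives > 40000 nM, which is a limit and not a number, so the true size of this step stays unknown. The series now sits largely at one end of the read-out: the limit of > 40000 nM in this assay, at which 3 of the 4 values shown sit.

Open, from the compounds shown here alone, is how an amine, a carboxylic acid or a longer chain on this nitrogen would read. Also open, going by these compounds, is whether any group here gives a value clearly lower than that of compound 2.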